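This account rests on a few compounds, and the source may have more. Where it says the series, first, only, none or still open, it means among the compounds named here.

Measured so far:
compound 1 `COc1ccc(C2=NN(c3ccccc3)C(c3ccc(C)cc3)C2S(=O)(=O)CC2=NCCO2)cc1`, 64.9%
compound 2 `COc1ccc(C2=NN(c3ccccc3)C(c3ccc(C)cc3)C2S(=O)(=O)CC2=NCCS2)cc1`, 44.9%
compound 3 `O=S(=O)(CC1=NCCS1)c1c(-c2ccccc2)noc1-c1ccccc1`, reported as "not active" (no number reported), with no number

In a functional assay, read by Griess assay, with a stated time of 150 min, tested at 75 ug/mL (a higher number here means a stronger effect of the compound at the concentration tested, a lower number a weaker effect), compound 1 gives 64.9% and compound 2 gives 44.9%. The step between them, a number 20 percentage points higher from compound 2 to compound 1 (beyond the scatter), follows from the change (a group of 5 heavy atoms (3 carbon, 1 nitrogen, 1 oxygen; one five-membered non-aromatic ring with 2 hetero atoms) in place of a group of 5 heavy atoms (3 carbon, 1 nitrogen, 1 sulfur; one five-membered non-aromatic ring with 2 hetero atoms), on a saturated chain carbon bound to a sulfonyl sulfur). Compound 3 was reported as not active in this assay, and no number exists for it. How the core of compound 3 differs from the core of compound 2 is not broken down here. Compound 4 `O=S(=O)(CC1=NCCO1)c1c(-c2ccccc2)noc1-c1ccccc1` has not been measured; it arises from compound 3 by a group of 5 heavy atoms (3 carbon, 1 nitrogen, 1 oxygen; one five-membered non-aromatic ring with 2 hetero atoms) in place of a group of 5 heavy atoms (3 carbon, 1 nitrogen, 1 sulfur; one five-membered non-aromatic ring with 2 hetero atoms), on a saturated chain carbon bound to a sulfonyl sulfur, the same change that turns compound 2 into compound 1. Since compound 3 starts from no measurable activity, a rise of the earlier size would still leave compound 4 weak, so a low read-out is expected, near 15%, between 0% and 40%, with a fair chance that it is again reported only as not active.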

Compound 4, a percentage reported as activity, at one concentration (the size of the read-out at that concentration, not a potency): 57.3%
Compound 4: middle estimate off by 42.3 percentage points, on the low side, outside the stated range (above it).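

Compound 3 carries no number, so no step from it to compound 4 can be read, and nothing measured here explains the result. The compounds shown leave open how large this group change's effect is on the core of compound 4.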